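The compounds below may be only part of what the source reports. "The series", "measured", "known", "first", "only" and "open" are said of these compounds alone.

Measured so far in a functional assay on A549 cells (Homo sapiens) for cytotoxicity, read by MTT assay, with a stated time of 72 h; a lower number here means a stronger inhibitor, a higher number a weaker inhibitor:
- compound 1, `CN(C)CCn1cnnc1-c1cc(Oc2ccc(NC(=O)N/N=C/c3ccc(O)c(Br)c3)cc2F)ccn1`: 1370 nM
- compound 2, `Cn1ncnc1-c1cc(Oc2ccc(NC(=O)N/N=C/c3ccccc3)cc2F)ccn1`: > 100000 nM

Compound 2 stands at the limit of this assay; its value of > 100000 nM is a limit, not a number, and the limit of > 100000 nM in this assay, at which 1 of the 2 values shown sits, marks where it sits. Going by the values given here, compound 1 returns a measured number, 1370 nM, but it differs from compound 2 in more than one place, so no single step between the two is set out and the two values show only that compound 1 is measurable while compound 2 is not.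

Compound 3, `Cn1cnnc1-c1cc(Oc2ccc(NC(=O)N/N=C/c3ccccc3)cc2F)ccn1`, is not yet measured in this assay. It differs from compound 2 by 4-methyl-4H-1,2,4-triazol-3-yl in place of 1-methyl-1H-1,2,4-triazol-5-yl on an aromatic carbon. Among the compounds with values here, with no measured step of this kind to lean on, the expected step of an at least 2.0-fold lower number from compound 2 to compound 3 (0.30 log units; that floor lies within the scatter) is a guess toward the measurable range, most of it resting on the fact that compound 2 sits at the limit and can only move one way. Compound 3 is expected to give about 50000 nM in this assay, within 8000 nM to 150000 nM, with a fair chance it also returns only a limit.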

Compound 3, half-maximal inhibitory concentration: 7560 nM
Beside the measured number, compound 3's estimate is 6.6-fold (0.82 log units) above it; the whole stated range lies above it.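

Going by these compounds alone, exchanging 1-methyl-1H-1,2,4-triazol-5-yl for 4-methyl-4H-1,2,4-triazol-3-yl, with the same atoms joined differently, gives the only single-place comparison so far in this assay: an at least 13-fold lower number from compound 2 to compound 3 (1.12 log units; beyond the scatter). On these data alone, the true size of this step is unknown because compound 2 gives a limit rather than a number: the limit of > 100000 nM in this assay, at which 1 of the 3 values shown sits. With everything else unchanged, the way the triazole is joined on an aromatic carbon next to the ring nitrogen is enough to bring the series within measurable range, and compound 3 gives 7560 nM.

As far as these compounds go, it remains open whether the step depends on the methyl group, which an ethyl group or a primary amine on the same triazole would test. Compound 1, at 1370 nM, differs from compound 3 in more than one place, so the contribution of each difference remains unresolved.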